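Swapping an Aryl Group for Neopentyl

This account rests on a few compounds, and the source may have more. Where it says the series, first, only, none or still open, it means among the compounds named here.

- compound 1 `O=C(NCc1cc(Cl)ccc1-n1cnnn1)[C@@H]1CC=NN1C(=O)[C@H](O)c1ccccc1F`: 1100 nM
- compound 2 `O=C([C@H](O)c1ccccc1)N1CC[C@@H]2C[C@@]21C(=O)NCc1cc(Cl)ccc1-n1cnnn1`: 1100 nM

In a functional assay on a cell-free system (plasma, Homo sapiens), with a stated time of 3 min (a lower number here means a stronger inhibitor, a higher number a weaker inhibitor), compound 1 gives 1100 nM, level with compound 2 at 1100 nM. Both compounds carry a six-membered aromatic ring of carbon only on the saturated chain carbon bound to a carbonyl carbon and an oxygen, and neither shows what happens without one. Compound 3 `CC(C)(C)C[C@@H](O)C(=O)N1N=CC[C@H]1C(=O)NCc1cc(Cl)ccc1-n1cnnn1` keeps the core of compound 1 and changes this group: neopentyl in place of 2-fluorophenyl on a saturated chain carbon bound to a carbonyl carbon and an oxygen on a saturated carbon. In words, it has neopentyl in place of 2-fluorophenyl on a saturated chain carbon bound to a carbonyl carbon and an oxygen on a saturated carbon. For the measured compounds named here, no measured pair tests this change, so the expectation is loose. The expected 1.4-fold higher number from compound 1 to compound 3 (0.13 log units; within the scatter) is a small weakening, hardly beyond the scatter. For compound 3 the estimated value is 1500 nM, with an expected range of 400 nM to 6000 nM.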

Compound 3, half-maximal inhibitory concentration: 590 nM
Estimate against measurement, compound 3: 2.5-fold (0.41 log units) above; the range from low to high includes it.
By their numbers in this assay, from the lowest: compounds 3, 1 and 2 (each within the scatter of the next).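

For the compounds shown here, replacing 2-fluorophenyl with neopentyl on a saturated chain carbon bound to a carbonyl carbon and an oxygen gives a 1.9-fold lower number from compound 1 to compound 3 (0.27 log units; within the scatter) in this assay and so shows what the earlier compounds could not: on the core of compound 1, an aromatic ring of carbon only is not needed at this place to keep inhibition in this range. The ring and the fluorine leave together in this one change, so their separate contributions cannot be told apart. Nothing available here explains the result.

The compounds shown leave open whether a smaller group such as methyl, or an amine or a carboxylic acid, would be accepted at this place. They also leave open whether neopentyl would give a similar result on the core of compound 2.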